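Trimming the Acetyl from a Benzylic Acetamide

A few compounds are considered here, and "the series" means these few. Any claim that something is new, unique, unknown or untested is made for them only; others in the source may bear on it.

Compound 2 `CC(=O)Nc1cccc(Cn2cc(-c3ccc4cn[nH]c4c3)ccc2=O)c1` stands at the highest number among the three compounds measured in an assay for inhibition of MAP kinase-interacting serine/threonine-protein kinase 1 (Homo sapiens), read by luminescence and ADP-Glo, with a stated time of 2 h (on this read-out lower numbers stand for stronger inhibition and higher numbers for weaker inhibition), where compound 2 gives 163 nM. Compound 1 `O=c1ccc(-c2ccc3cn[nH]c3c2)cn1Cc1ccccc1C(F)(F)F` gives 133 nM, a value within the scatter of compound 2. Compound 3 `Nc1n[nH]c2cc(-c3ccc(=O)n(Cc4cccc(Cl)c4)c3)ccc12` gives 11 nM, a far lower number. Compound 4 `Nc1cccc(Cn2cc(-c3ccc4cn[nH]c4c3)ccc2=O)c1` differs from compound 2 by hydrogen in place of acetyl on a nitrogen on an aromatic ring. Within the data shown here, no measured pair in this set shows the same change, so the size of the step is open. Since only a small piece is removed, the expected step from compound 2 to compound 4 in this assay is a 1.3-fold lower number from compound 2 to compound 4 (0.10 log units; within the scatter), in no direction beyond the scatter. Compound 4 is therefore estimated to give 130 nM in this assay, with a range of 45 nM to 400 nM.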

Compound 4, half-maximal inhibitory concentration: 287 nM
Compound 4: middle estimate off by 2.2-fold (0.34 log units), on the low side; the measured number falls inside the stated range.
By their numbers in this assay, from the lowest: compound 3; then compounds 1, 2 and 4 (each within the scatter of the next, the first and the last beyond it).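

Swapping acetyl for hydrogen on a nitrogen on an aromatic ring, acetamido to amino, gives a 1.8-fold higher number from compound 2 to compound 4 (0.25 log units; within the scatter) in this assay. The acetyl is therefore not shown to matter for the number at this place, and the free amino group is tolerated in this assay. Nothing available here accounts for the size of this step. Still open, as far as these compounds go, is whether a methanesulfonyl group or a longer acyl chain on this nitrogen would move the number beyond the scatter. From the compounds shown here alone, whether the same change behaves alike on the core of compound 3 is also open.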